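Dropping the Amino Group: What Vero Cells Tolerate

The compounds below may be only part of what the source reports. "The series", "measured", "known", "first", "only" and "open" are said of these compounds alone.

Compound 1 `COc1ccc(-c2nc3cc(C(F)(F)F)ccc3[nH]2)c(N)c1` and compound 2 `COc1cc(-c2nc3cc(C(F)(F)F)ccc3[nH]2)cc(OC)c1OC` share one core and were both examined in an ADME assay on Vero cells (Chlorocebus sabaeus) for cytotoxicity; a lower number here means that less compound is tolerated, a higher number that more compound is tolerated. In this assay compound 1 gives 50000 nM, the higher of the two figures, yet compound 2 gives 29000 nM and the gap lies within the scatter, so the pair is not distinguished. Compound 3 `COc1ccc(-c2nc3cc(C(F)(F)F)ccc3[nH]2)cc1` has not yet been measured. It differs from compound 1 in a single place: hydrogen in place of amino on an aromatic carbon. Among the measured compounds shown here, no measured pair shows the effect of such a change, so the step of a 1.3-fold lower number from compound 1 to compound 3 (0.10 log units; within the scatter) is expected to stay within the scatter. The tolerated concentration of compound 3 is estimated at 40000 nM, between 18000 nM and 90000 nM.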

Compound 3, half-maximal cytotoxic concentration: 15000 nM
Compound 3: middle estimate off by 2.7-fold (0.43 log units), on the high side, and the stated range ends above it.
By their numbers in this assay, from the lowest: compounds 3, 2 and 1 (each within the scatter of the next, the first and the last beyond it).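

In this assay, the amino group on this aromatic carbon, ortho to a large group and meta to a methoxy group, proves not to be interchangeable with hydrogen: the exchange gives a 3.3-fold lower number from compound 1 to compound 3 (0.52 log units; beyond the scatter) and so moves the tolerated concentration modestly but beyond the scatter. This is the only single-place step available, so the effect is shown for this one pair alone. Nothing at hand accounts for the step.

As far as these compounds go, whether a hydroxyl group, a methyl group or an acetamide on this carbon would match compound 1 remains open. So does whether the amino group has the same effect with the methoxy group replaced by an ethoxy group.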